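Anilide in place of acid on a second core

A few compounds are considered here, and "the series" means these few. Any claim that something is new, unique, unknown or untested is made for them only; others in the source may bear on it.

Measured so far:
compound 1, `C=CC1=C(C(=O)O)C(c2ccc(F)cc2)OC1`: > 100000 nM
compound 2, `C=CC1=C(C(=O)Nc2ccccc2)C(c2ccc(F)cc2)OC1`: > 100000 nM
compound 3, `C=CC1=C(C(=O)O)C(c2ccc(OC)c(OC)c2)OC1`: > 100000 nM

In a functional assay on A549 cells (Homo sapiens) for cytotoxicity, read by MTT assay, with a stated time of 24 h (a higher number here means a weaker inhibitor, a lower number a stronger inhibitor), compound 1 gives > 100000 nM, which is a limit of the assay and not a number. Compound 2 likewise gives only a limit, > 100000 nM. Compound 3 gives only a limit too, > 100000 nM. The change from compound 1 to compound 2 is anilino in place of hydroxy on a carbonyl carbon, and its step that the two limits leave unreadable from compound 1 to compound 2 cannot be read because of the limit of > 100000 nM in this assay, at which 3 of the 3 values shown sit. Compound 4, `C=CC1=C(C(=O)Nc2ccccc2)C(c2ccc(OC)c(OC)c2)OC1`, carries the same change on the core of compound 3: anilino in place of hydroxy on a carbonyl carbon. How the two cores differ is not broken down here. For this step an expected size of a step that the limit leaves unreadable from compound 3 to compound 4 rests on compound 1 and compound 2 both sitting at the limit, (the limit of > 100000 nM in this assay, at which 3 of the 3 values shown sit). Compound 4 is therefore expected to give about 150000 nM, between 40000 nM and 600000 nM, most likely again only a limit.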

Compound 4, half-maximal inhibitory concentration: > 100000 nM
Compound 4 ended at the assay's limit; the forecaster's own chance of this, stated with the estimate: 80%; the middle value does not contradict the limit.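

Compound 3 and compound 4 both sit at a limit of the assay, not at a number, so the step between them cannot be read: the limit of > 100000 nM in this assay, at which 4 of the 4 values shown sit.

From the compounds shown here alone, whether anilino in place of hydroxy changes the result at all in this assay stays open for these compounds.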